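Working notes: from compound 2 to compound 3

The source may report more compounds than this note shows. Statements on the series, on what has been measured and on what is new or still open speak of the compounds shown alone.

Measured in a functional assay on MIA PaCa-2 cells (Homo sapiens) for cytotoxicity, read by MTT assay, with a stated time of 24 h; on this read-out lower numbers stand for stronger inhibition and higher numbers for weaker inhibition:
- compound 1 `CC[C@H](C)[C@@H](O)C(=O)O[C@@H](C(=O)O[C@@H](C(=O)O[C@@H](C(=O)O[C@@H](C(=O)OC[C@@H](O)[C@@H](O)[C@H](O)CO)[C@@H](C)CC)[C@@H](C)CC)[C@@H](C)CC)[C@@H](C)CC`: > 55400 nM (a limit)
- compound 2 `CC[C@H](C)[C@@H](O)C(=O)O[C@@H](C(=O)O[C@@H](C(=O)O[C@@H](C(=O)O[C@@H](C(=O)O[C@@H]([C@H](O)[C@H](O)CO)[C@H](O)CO)[C@@H](C)CC)[C@@H](C)CC)[C@@H](C)CC)[C@@H](C)CC`: > 53200 nM (a limit)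

Not yet measured:
- compound 3 `CC[C@H](C)[C@@H](O)C(=O)O[C@@H](C(=O)O[C@@H](C(=O)O[C@@H](C(=O)O[C@@H](C(=O)O[C@H](CO)[C@@H](O)[C@H](O)[C@H](O)CO)[C@@H](C)CC)[C@@H](C)CC)[C@@H](C)CC)[C@@H](C)CC`

Compound 2 has no numerical value, only the limit > 53200 nM. Compound 1 is also known only as a limit, > 55400 nM.

The change under study is 2,3,4,5-tetrahydroxy-1-(hydroxymethyl)pentyl in place of 1-(1,2-dihydroxyethyl)-2,3,4-trihydroxybutyl on an oxygen next to a carbonyl group. In words, 2,3,4,5-tetrahydroxy-1-(hydroxymethyl)pentyl stands in place of 1-(1,2-dihydroxyethyl)-2,3,4-trihydroxybutyl on an oxygen next to a carbonyl group.

Going by the values given here, the one measured step that bears on this change is a step that the two limits leave unreadable from compound 1 to compound 2, which also replaces one group on that oxygen with another. It gives no size to carry over, so no step beyond the scatter is expected in this assay, and another limit is the likeliest result. The expected step is a step that the limit leaves unreadable from compound 2 to compound 3. The estimated value for compound 3 is 55000 nM, with an expected range of 30000 nM to 100000 nM.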

Compound 3, half-maximal inhibitory concentration: > 53200 nM
Compound 3: a limit, no number; the forecaster's own chance of this, stated with the estimate: 85%; the middle value is on the limit's open side.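

In this assay compound 3 gives > 53200 nM, a limit and not a number. Going by these compounds alone, compound 1, compound 2 and compound 3 are all known only as limits, so no step among them can be read. Going by these compounds, whether these groups on the oxygen next to a carbonyl group differ at all in this assay remains open.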